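Dropping the Ester from a Nitrophenyl Triazole Amide

This account rests on a few compounds, and the source may have more. Where it says the series, first, only, none or still open, it means among the compounds named here.

Four compounds share one core built from a five-membered ring bearing a methyl group, joined through an amide to a triazole that carries a substituted phenyl ring. Compound 1 `CCOC(=O)c1sc(NC(=O)Cn2cc(-c3ccc(OC)cc3)nn2)nc1C` gives 2330 nM in a functional assay on BMDM cells (Mus musculus, strain C57BL/6) for inhibition, with a stated time of 2 days; a lower number here means a stronger inhibitor, a higher number a weaker inhibitor. Compound 2 `COc1ccc(-c2cn(CC(=O)Nc3nc(C)cs3)nn2)cc1` gives 3890 nM in this assay, and the change between them is hydrogen in place of ethoxycarbonyl on an aromatic carbon, with a step of a 1.7-fold higher number from compound 1 to compound 2 (0.22 log units; within the scatter). Compound 3 `CCOC(=O)c1sc(NC(=O)Cn2cc(-c3ccc([N+](=O)[O-])cc3)nn2)nc1C` gives 1840 nM in this assay; it differs from compound 1 by nitro in place of methoxy on an aromatic carbon, a step of a 1.3-fold lower number from compound 1 to compound 3 (0.10 log units; within the scatter). Among these three, compound 3 has the lowest number, though its gap to compound 1 lies within the scatter.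

Compound 4 `Cc1csc(NC(=O)Cn2cc(-c3ccc([N+](=O)[O-])cc3)nn2)n1` has not yet been measured. It differs from compound 3 by hydrogen in place of ethoxycarbonyl on an aromatic carbon. This is the same change that turns compound 1 into compound 2, made on the same place of the ring, so the cores differ only in the way described for compound 1 against compound 3.

In this assay the expected step is a 1.7-fold higher number from compound 3 to compound 4 (0.23 log units; within the scatter). Among the compounds with values here, that expectation rests on a 1.7-fold higher number from compound 1 to compound 2 (0.22 log units; within the scatter), the one measured example of this change, which stayed within the scatter. Compound 4 is therefore estimated at 3100 nM, most likely between 1500 nM and 6500 nM. Within the data shown here, with only a single prior example, the range is kept wide.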

Compound 4, half-maximal inhibitory concentration: 190 nM
For compound 4 the middle estimate is 16-fold (1.21 log units) above the measured one; measured number below the stated range.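

In this assay, hydrogen in place of ethoxycarbonyl on the core carrying the nitro group gives a 9.7-fold lower number from compound 3 to compound 4 (0.99 log units; beyond the scatter), and this does not match what the same swap does on the core carrying the methoxy group: the same change on two cores in this assay, a 1.7-fold higher number (0.22 log units; within the scatter) from compound 1 to compound 2 and a 9.7-fold lower number (0.99 log units; beyond the scatter) from compound 3 to compound 4, 16-fold (1.21 log units) apart, beyond the scatter of two such steps. Seen from the other side, nitro in place of methoxy on the core without the ester gives a 20-fold lower number from compound 2 to compound 4 (1.31 log units; beyond the scatter), and this does not match that change on the core with the ester: the same change on two cores in this assay, a 1.3-fold lower number (0.10 log units; within the scatter) from compound 1 to compound 3 and a 20-fold lower number (1.31 log units; beyond the scatter) from compound 2 to compound 4, 16-fold (1.21 log units) apart, beyond the scatter of two such steps. In these four compounds, then, the effect of each change depends on which group sits at the other place, so a step measured on one core cannot simply be carried to another, but four compounds cannot explain why this happens or show how either change would behave on any further core.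

The compounds shown leave open whether the low number of compound 4 requires the nitro group or would also appear with a nitrile or a trifluoromethyl group on the phenyl ring of the core without the ester. Also open, going by these compounds, is what a carboxylic acid or an amine would do in the place that ethoxycarbonyl leaves in compound 4.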